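Cytotoxicity limit holds so far; sulfonyl aryl swap next

The compounds below may be only part of what the source reports. "The series", "measured", "known", "first", "only" and "open" are said of these compounds alone.

In a functional assay on HEK293 cells (Homo sapiens) for cytotoxicity (a higher number here means that more compound is tolerated, a lower number that less compound is tolerated), compound 1 `COc1ccc([C@H]2CC(=O)N(c3cccc(C(F)(F)F)c3)C2)cc1OC1CCCC1` gives > 10000 nM as a limit, not a number. Compound 2 `COc1ccc([C@H]2CC(=O)N(c3cccc([S+](C)[O-])c3)C2)cc1OC1CCCC1` gives > 10000 nM, again a limit. Compound 3 `COc1ccc(S(=O)(=O)Nc2cccc(N3C[C@@H](c4ccc(OC)c(OC5CCCC5)c4)CC3=O)c2)cc1` gives > 10000 nM, also a limit, so its standing is known only as that limit. The series so far reads as the limit of > 10000 nM in this assay, at which 3 of the 3 values shown sit, and holds no exception among these three compounds.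

Compound 4 `COc1ccc([C@H]2CC(=O)N(c3cccc(NS(=O)(=O)c4cccc(F)c4)c3)C2)cc1OC1CCCC1`, not yet measured, carries 3-fluorophenyl in place of 4-methoxyphenyl on a sulfonyl sulfur and is otherwise the same as compound 3.

Going by the values given here, three measured steps bear on this only loosely: a step that the two limits leave unreadable from compound 1 to compound 2 and a step that the two limits leave unreadable from compound 1 to compound 3 and a step that the two limits leave unreadable from compound 2 to compound 3 have no size that can be used. Among the compounds with values here, none of them alters the aryl group on the sulfonyl sulfur, so no measured step speaks to this swap directly.

No clear change is expected in this assay because compound 3 gives > 10000 nM as a limit, as do both other measured compounds. The estimated step is a step that the limit leaves unreadable from compound 3 to compound 4 and another limit is the likeliest report. The expected value for compound 4 is 15000 nM within an estimated range of 5000 nM to 40000 nM as half-maximal cytotoxic concentration.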

Compound 4, half-maximal cytotoxic concentration: > 10000 nM
Compound 4: only a limit was reported; the forecaster's own chance of this, stated with the estimate: 85%; the middle value lies beyond the limit too.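

Compound 4 also gives only a limit in this assay, and its steps from compound 1, compound 2 and compound 3 cannot be read, so the series still stands at a single reading: the limit of > 10000 nM in this assay, at which 4 of the 4 values shown sit.

The compounds shown leave open the concentration at which any of them becomes cytotoxic, and whether 3-fluorophenyl and 4-methoxyphenyl on the sulfonyl sulfur differ at all in this assay.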